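Clearance notes: from compound 3 to compound 4

The source may hold more compounds than are shown below. What is called first, only, known or untested is meant among the compounds shown, and "the series" means these compounds.

Measured in an ADME assay on the whole organism (Rattus norvegicus, strain Sprague-Dawley) for pharmacokinetics, using cassette dosing, at a dose of 0.5 mg/kg by the intravenous route; a higher number here means faster removal of the compound, a lower number slower removal:
- compound 1 `O=C(c1cc(-c2cn[nH]c2)on1)N1CCC(Cc2ccc(Cl)cc2)CC1`: 29.2 mL/min/kg
- compound 2 `O=C(c1cc(-c2ccc(=O)[nH]c2)on1)N1CCC(Cc2ccc(F)cc2)CC1`: 19.7 mL/min/kg
- compound 3 `O=C(Nc1ccc2[nH]c(=O)oc2c1)C(=O)N1CCN(c2ccc(F)cc2)CC1`: 11.1 mL/min/kg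

In this assay compound 3 at 11.1 mL/min/kg lies within the usual scatter of compound 2 at 19.7 mL/min/kg, while compound 1 at 29.2 mL/min/kg stands beyond that scatter with the higher number. Compound 4 `O=C(Nc1ccc2[nH]c(=O)oc2c1)C(=O)N1CCN(c2ccc(F)c(F)c2)CC1` differs from compound 3 by fluoro in place of hydrogen on an aromatic carbon, 4-fluorophenyl to 3,4-difluorophenyl. Within the data shown here, no two measured compounds differ in one place only, so the data offer no direct guide to this change. The expected size, a 1.1-fold higher number from compound 3 to compound 4 (0.03 log units; within the scatter), is slight, with no direction beyond the scatter in this assay. Compound 4 is estimated at 12 mL/min/kg, with an expected range of 6.5 mL/min/kg to 22 mL/min/kg.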

Compound 4, clearance: 4 mL/min/kg
Beside the measured number, compound 4's estimate is 3.0-fold (0.48 log units) above it; the whole stated range lies above it.
By their numbers in this assay, from the lowest: compound 4; then compounds 3, 2 and 1 (each within the scatter of the next, the first and the last beyond it).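

In this assay, among these compounds, fluoro in place of hydrogen on an aromatic carbon, ortho to a fluoro group and meta to a large group, gives a 2.8-fold lower number from compound 3 to compound 4 (0.44 log units; beyond the scatter), the only single-place step. This position therefore responds to a single added heavy atom: 4-fluorophenyl to 3,4-difluorophenyl alone lowers clearance beyond the scatter. Nothing at hand accounts for the drop. Open, as far as these compounds go, is whether chloro, methyl or methoxy at this position would shift clearance likewise. Also open, from the compounds shown here alone, is whether the same change would carry over to the core of compound 2.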